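Notes on a sulfonyl enone series: compound 3 to compound 4

The source may report more compounds than this note shows. Statements on the series, on what has been measured and on what is new or still open speak of the compounds shown alone.

Three compounds of this series have numbers in a functional assay on DU-145 cells (Homo sapiens) for inhibition, read by trypan blue exclusion, with a stated time of 96 h; a higher number here means a weaker inhibitor of growth, a lower number a stronger inhibitor of growth. Compound 1 `Nc1c(Br)cc(Br)cc1/C=C(\C(=O)c1ccc(Br)cc1)S(=O)(=O)c1ccc(Br)cc1` gives 25000 nM. Compound 2 `Cc1ccc(/C=C(\C(=O)c2ccc(Cl)cc2)S(=O)(=O)Cc2ccc(Cl)cc2Cl)s1` gives 10000 nM. Compound 3 `Cc1ccc(CS(=O)(=O)/C(=C/c2ccc(S(C)(=O)=O)cc2)C(=O)c2ccc(Br)cc2)cc1` gives 10000 nM, level with compound 2 at the digits shown, the two together the lowest of the three numbers; compound 1 stands furthest from compound 3, beyond the scatter. For the measured compounds named here, no pair of measured compounds differs in only one place, so the series itself gives no guide to the size of a single change. Compound 4 `CSc1ccc(/C=C(\C(=O)c2ccc(Br)cc2)S(=O)(=O)Cc2ccc(C)cc2)cc1` differs from compound 3 by methylsulfanyl in place of methylsulfonyl on an aromatic carbon. Going by the values given here, with no measured step to rest on, the step of no change at the digits printed from compound 3 to compound 4 (within the scatter) is expected to stay within the scatter, in neither direction. Compound 4 is estimated at 10000 nM, with a range of 4000 nM to 25000 nM.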

Compound 4, concentration for 50% growth inhibition: 10000 nM
Compound 4: the middle estimate sits on the measured number at the digits printed; the range from low to high includes it.
By their numbers in this assay, from the lowest: compounds 2, 3 and 4 (each within the scatter of the next); then compound 1.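

The series now has its first single-place step: in this assay, methylsulfanyl in place of methylsulfonyl on an aromatic carbon, para to a large group, gives no change at the digits printed from compound 3 to compound 4 (within the scatter). At this position, the smaller group can therefore replace the larger one on this core without a change beyond the scatter. No measurement on hand offers an explanation for this result.

On these data alone, whether an amine or a carboxylic acid at this position would also stay within the scatter remains open. So does the outcome for a longer chain on the sulfur.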